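Aryl urea variation on a shared core: working notes

This account rests on a few compounds, and the source may have more. Where it says the series, first, only, none or still open, it means among the compounds named here.

Measured in a functional assay on HepG2 cells (Homo sapiens) for antiproliferative activity, read by MTT assay, with a stated time of 48 h; on this read-out higher numbers stand for weaker inhibition and lower numbers for stronger inhibition:
compound 1 `O=C(Nc1ccccc1)Nc1nnc(Sc2ncnc3scc(-c4ccncc4)c23)s1` gives 19400 nM
compound 2 `O=C(Nc1cccc(C(F)(F)F)c1)Nc1nnc(Sc2ncnc3scc(-c4ccncc4)c23)s1` gives 15300 nM
compound 3 `Cc1ccc(NC(=O)Nc2nnc(Sc3ncnc4scc(-c5ccncc5)c34)s2)cc1Cl` gives 16000 nM

All three share one core and differ only in the aryl group on the urea nitrogen. Compound 3 sits second highest of the three numbers, with compound 2 nearest and compound 1 furthest, and both gaps within the scatter. The steps bear this out: a 1.3-fold lower number from compound 1 to compound 2 (0.10 log units; within the scatter) and a 1.2-fold lower number from compound 1 to compound 3 (0.08 log units; within the scatter) are both within the scatter, as is a 1.0-fold higher number from compound 2 to compound 3 (0.02 log units; within the scatter). Going by the values given here, nothing among the measured compounds separates one aryl urea from another on this read-out.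

Compound 4 `O=C(Nc1ccc(Cl)c(Cl)c1)Nc1nnc(Sc2ncnc3scc(-c4ccncc4)c23)s1` is not yet measured. Its difference from compound 3 is chloro in place of methyl on an aromatic carbon. The measured steps that bear on it are the aryl swaps among compounds 1, 2 and 3, all of which left the number essentially unchanged. Exchanging methyl for chloro at the same spot on the ring is a smaller move than any of those, so no step beyond the scatter is expected in this assay. The estimate for compound 4 is 15000 nM, with a range of 7000 nM to 35000 nM, which means an expected step of a 1.1-fold lower number from compound 3 to compound 4 (0.03 log units; within the scatter).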

Compound 4, half-maximal inhibitory concentration: 61900 nM
Beside the measured number, compound 4's estimate is 4.1-fold (0.62 log units) below it; the whole stated range lies below it.
By their numbers in this assay, from the lowest: compounds 2, 3 and 1 (each within the scatter of the next); then compound 4.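

In this assay, going by these compounds alone, chloro in place of methyl, on the aromatic carbon para to a large group and ortho to a chloro group, gives a 3.9-fold higher number from compound 3 to compound 4 (0.59 log units; beyond the scatter) and is the first step to leave the scatter, towards weaker inhibition. This carbon of the aryl ring is therefore not indifferent to what it carries, even though the exchange is one heavy atom for one heavy atom and phenyl, 3-(trifluoromethyl)phenyl and 3-chloro-4-methylphenyl could not be told apart. The 3,4-dichlorophenyl urea also stands apart from the other two, with a 4.0-fold higher number from compound 2 to compound 4 (0.61 log units; beyond the scatter) and a 3.2-fold higher number from compound 1 to compound 4 (0.50 log units; beyond the scatter) on the same read-out, and nothing measured here accounts for this separation.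

On these data alone, whether the step belongs to chloro on this carbon alone or to the two chloro groups together stays open. A methoxy group or an amine on the same carbon, with the neighbouring chloro group kept, would show whether the number responds to other groups here or only to chloro.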